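A few compounds are considered here, and "the series" means these few. Any claim that something is new, unique, unknown or untested is made for them only; others in the source may bear on it.

Measured compounds:
- compound 1, `Cc1cc(NC(=O)C2C(C)(C)C2(C)C)ccc1N1CCC(N2CCCC2C)C1`: 65.5 nM
- compound 2, `CC1CCCN1C1CCN(c2ccc(NC(=O)C3C(C)(C)C3(C)C)cc2)C1`: 144 nM
- compound 3, `Cc1cc(N2CC[C@@H](N3CCC[C@@H]3C)C2)ccc1NC(=O)C1CCOCC1`: 3.9 nM

In an assay on CHO cells for displacement of a labelled ligand from histamine receptor H3 (Macaca mulatta) (a lower number here means a stronger inhibitor, a higher number a weaker inhibitor), compound 1 gives 65.5 nM, the second highest of the three numbers. Its nearest neighbour is compound 2, where the step of a 2.2-fold higher number from compound 1 to compound 2 (0.34 log units; beyond the scatter) corresponds to hydrogen in place of methyl on an aromatic carbon. Compound 3 carries a different acyl group on the amide and stands far lower, at 3.9 nM against 65.5 nM for compound 1.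

Compound 4, `Cc1cc(NC(=O)C2CC2)ccc1N1CCC(N2CCCC2C)C1`, is not yet measured. It differs from compound 1 by cyclopropyl in place of 2,2,3,3-tetramethylcyclopropyl on a carbonyl carbon. Among the compounds with values here, none of the measured steps touches the group on the carbonyl carbon, so no step bears directly on this change; the only hint is that compound 3, with another group at that position, gives 3.9 nM, well under compound 1. The account therefore expects compound 4 to come out in this assay at a number no higher than compound 1, possibly somewhat lower, as a 1.5-fold lower number from compound 1 to compound 4 (0.16 log units; within the scatter). The estimate for compound 4 in this assay is 45 nM, with a range from 12 nM to 170 nM.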

Compound 4, inhibition constant: 17.7 nM
For compound 4 the middle estimate is 2.5-fold (0.41 log units) above the measured one; the measured number falls inside the stated range.
By their numbers in this assay, from the lowest: compound 3; then compound 4; then compound 1; then compound 2.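

In this assay, the group on the carbonyl carbon now has a step of its own: with cyclopropyl in place of 2,2,3,3-tetramethylcyclopropyl, the change is a 3.7-fold lower number from compound 1 to compound 4 (0.57 log units; beyond the scatter). Both groups hold a three-membered ring of carbon only, and the heavy atoms fall from 7 to 3, so within this pair the position tolerates the loss of the methyl groups and the smaller group gives the lower number. Nothing available explains this shift.

Compound 3 differs from compound 4 in more than one place, so the part its acyl group plays in its value cannot be separated out. From the compounds shown here alone, how a cyclobutyl ring, a longer chain such as butyl, or an amine would read on this carbonyl carbon remains open.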